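The source may report more compounds than this note shows. Statements on the series, on what has been measured and on what is new or still open speak of the compounds shown alone.

Of the compounds shown here, three built on a shared core have so far been tested in a functional assay on MCF7 cells (Homo sapiens) for cytotoxicity, read by sulforhodamine B assay, with a stated time of 48 h; a lower number here means that less compound is tolerated, a higher number that more compound is tolerated. Compound 1 `COc1cc(/C(Cl)=C/C=C(\C#N)C(=O)c2c(C)[nH]c3ccccc23)cc(OC)c1OC` gives > 100000 nM, which is a limit of the assay rather than a number. Compound 2 `N#C/C(=C\C=C(/Cl)c1ccc(Br)cc1)C(=O)c1c[nH]c2ccc(Br)cc12` likewise reaches only the limit > 100000 nM. Compound 3 `COc1ccc(/C(Cl)=C/C=C(\C#N)C(=O)c2c[nH]c3ccc(Br)cc23)cc1` also stops at the limit > 100000 nM. For the measured compounds named here, the one step that connects two of these, methoxy in place of bromo on an aromatic carbon, a step that the two limits leave unreadable from compound 2 to compound 3, is not readable in size; both of its ends are limits. Compound 2 thus stands at the limit and nowhere among readable numbers, and all three values shown sit at that same point, (the limit of > 100000 nM in this assay, at which 3 of the 3 values shown sit).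

Compound 4 `N#C/C(=C\C=C(/Cl)c1ccc(Br)cc1)C(=O)c1c[nH]c2ccccc12` is still to be measured in this assay. It differs from compound 2 by hydrogen in place of bromo on an aromatic carbon. Going by the values given here, no measured step here carries hydrogen in place of bromo on an aromatic carbon, and the only step that exists, a step that the two limits leave unreadable from compound 2 to compound 3, offers no size to lean on. Among the compounds with values here, what can be said rests on the fact that every value so far sits at the limit, (the limit of > 100000 nM in this assay, at which 3 of the 3 values shown sit). Compound 4 is therefore expected to lie around 100000 nM, within a range from 30000 nM to 300000 nM. The step this estimate implies, a number no higher from compound 2 to compound 4 (the limit leaves the size open), is expected to be none beyond the scatter, with a real chance that only a limit is again reported.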

Compound 4, concentration lethal to 50% of the cells: > 100000 nM
Compound 4: only a limit was reported; the forecaster's own chance of this, stated with the estimate: 75%; the middle value lies on the limit itself.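

Compound 4, like compound 2, ends at a limit of the assay rather than a number, so the step between them, hydrogen in place of bromo on an aromatic carbon, cannot be read. How far any change on the shared core moves the lethal concentration in this assay stays open, with no readable number among the compounds shown: the limit of > 100000 nM in this assay, at which 4 of the 4 values shown sit.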